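Substituent swaps on the shared aromatic ring

The source may hold more compounds than are shown below. What is called first, only, known or untested is meant among the compounds shown, and "the series" means these compounds.

Measured so far:
compound 1 `N#CC1CN1C(=O)Nc1ccc(F)cc1`, 5900 nM
compound 2 `CCOC(=O)c1ccc(NC(=O)N2CC2C#N)cc1`, 7700 nM
compound 3 `N#CC1CN1C(=O)Nc1ccc(C(F)(F)F)cc1`, 5900 nM

In a functional assay on OVCAR-3 cells (Homo sapiens) for inhibition (a higher number here means a weaker inhibitor, a lower number a stronger inhibitor), compound 3 gives 5900 nM, level with compound 1 at the digits shown and together the lowest of the three numbers; the step of a 1.3-fold lower number from compound 2 to compound 3 (0.12 log units; within the scatter) lies within the scatter. Compound 4 `N#CC1CN1C(=O)Nc1ccc(S(N)(=O)=O)cc1` carries the change (sulfamoyl in place of trifluoromethyl on an aromatic carbon). Going by the values given here, no measured step introduces a sulfamoyl; the nearest comparisons are the substituent swaps on the same aromatic carbon, a 1.3-fold higher number from compound 1 to compound 2 (0.12 log units; within the scatter) and no change at the digits printed from compound 1 to compound 3 (within the scatter), both within the scatter. Three different substituents at that carbon thus left this assay essentially unchanged, so for the present change no step beyond the scatter is expected, a 1.0-fold higher number from compound 3 to compound 4 (0.01 log units; within the scatter). Compound 4 is estimated at 6000 nM, range 3000 nM to 13000 nM.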

Compound 4, half-maximal inhibitory concentration: 188000 nM
The estimate for compound 4 lay 31-fold (1.50 log units) below the measured number; the whole stated range lies below it.
By their numbers in this assay, from the lowest: compounds 1, 3 and 2 (each within the scatter of the next); then compound 4.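

This aromatic carbon is not indifferent to substitution in this assay: sulfamoyl gives a 32-fold higher number from compound 3 to compound 4 (1.50 log units; beyond the scatter) and a 32-fold higher number from compound 1 to compound 4 (1.50 log units; beyond the scatter) and also a 24-fold higher number from compound 2 to compound 4 (1.39 log units; beyond the scatter) while fluoro, trifluoromethyl and ethoxycarbonyl remain within the scatter of one another. Against trifluoromethyl, sulfamoyl has the same count of 4 heavy atoms but brings 1 hydrogen-bond donor and 2 hydrogen-bond acceptors, so heavy-atom count alone does not separate the two groups. No available measurement accounts for the loss.

Open, on these data alone, is whether the loss is specific to sulfamoyl or extends to other groups on this carbon, such as methylsulfonyl, a carboxylic acid or an amine.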